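The source may hold more compounds than are shown below. What is called first, only, known or untested is meant among the compounds shown, and "the series" means these compounds.

In a functional assay on SF-268 cells (Homo sapiens) for cytotoxicity, read by MTT assay, with a stated time of 3 days (a lower number here means a stronger inhibitor, a higher number a weaker inhibitor), three compounds sharing one core have been measured. Compound 1 `N#Cc1c(Nc2ccccc2)nc(SCc2nc3ccccc3[nH]2)nc1-c1ccccc1` gives 4.46 nM, compound 2 `N#Cc1c(Nc2ccccn2)nc(SCc2nc3ccccc3[nH]2)nc1-c1ccccc1` gives 6.75 nM and compound 3 `N#Cc1c(Nc2nccs2)nc(SCc2nc3ccccc3[nH]2)nc1-c1ccccc1` gives 2.55 nM. For the measured compounds named here, these compounds differ only in the aromatic group on the nitrogen, and swapping that group moves the number little: a 1.5-fold higher number from compound 1 to compound 2 (0.18 log units; within the scatter), a 1.7-fold lower number from compound 1 to compound 3 (0.24 log units; within the scatter) and, the only step past the scatter, a 2.6-fold lower number from compound 2 to compound 3 (0.42 log units; beyond the scatter). Compound 3 thus stands apart from compound 2 but cannot be separated from compound 1.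

Compound 4 `CN1CCN(c2nc(SCc3nc4ccccc4[nH]3)nc(-c3ccccc3)c2C#N)CC1` brings a different kind of change, with 4-methylpiperazin-1-yl in place of (1,3-thiazol-2-yl)amino on an aromatic carbon. Going by the values given here, no measured compound has a non-aromatic ring at this place, so the small steps above offer only loose guidance. Starting from compound 3 at 2.55 nM, a modest rise in the number is expected, with wide uncertainty. The expected change is a 3.5-fold higher number from compound 3 to compound 4 (0.55 log units; beyond the scatter). For compound 4 the estimated value is 9 nM, with an expected range from 2 nM to 40 nM.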

Compound 4, half-maximal inhibitory concentration: 6.9 nM
For compound 4 the middle estimate is 1.3-fold (0.12 log units) above the measured one, within the range that was stated.
By their numbers in this assay, from the lowest: compounds 3, 1, 2 and 4 (each within the scatter of the next, the first and the last beyond it).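

Until now, every group at this position carried an aromatic ring on an amino nitrogen. In this assay the 4-methylpiperazin-1-yl group, a six-membered non-aromatic ring with 0 hydrogen-bond donors, stays level with the anilino and (pyridin-2-yl)amino compounds (a 1.0-fold higher number from compound 2 to compound 4 (0.01 log units; within the scatter); a 1.5-fold higher number from compound 1 to compound 4 (0.19 log units; within the scatter)), so neither an aromatic ring nor a donor at this place is required to reach numbers of this size. Only the (1,3-thiazol-2-yl)amino compound separates from it (a 2.7-fold higher number from compound 3 to compound 4 (0.43 log units; beyond the scatter)), and no measured evidence accounts for that gap.

Going by these compounds, whether the methyl group matters remains open, as a plain piperazin-1-yl group would be needed to test it. Also open, on these data alone, is whether other saturated rings, such as morpholin-4-yl, or an open-chain amine such as dimethylamino would fit this place equally well.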